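Swapping cyclopentyl for 3-hydroxypropyl on compound 3

A few compounds are considered here, and "the series" means these few. Any claim that something is new, unique, unknown or untested is made for them only; others in the source may bear on it.

Measured so far in a functional assay on KB cells (Homo sapiens) for antiproliferative activity, read by sulforhodamine B assay, with a stated time of 48 h; on this read-out lower numbers stand for stronger inhibition of growth and higher numbers for weaker inhibition of growth
compound 1 `COc1ccc(Nc2nc(NC3CCCC3)c3ccccc3n2)cc1` gives 11100 nM
compound 2 `COc1ccc(Nc2nc(NCCCO)c3ccccc3n2)cc1` gives 20300 nM
compound 3 `COc1ccc(N(C)c2nc(NC3CCCC3)c3ccccc3n2)cc1` gives 11700 nM

All three values lie within the usual scatter of one another, so no order can be read among them, and compound 3 stands together with the other two. In compound 4 `COc1ccc(N(C)c2nc(NCCCO)c3ccccc3n2)cc1`, 3-hydroxypropyl takes the place of cyclopentyl on a nitrogen on an aromatic ring (3-hydroxypropyl in place of cyclopentyl on a nitrogen on an aromatic ring). The same swap, measured without the methyl, gave a 1.8-fold higher number from compound 1 to compound 2 (0.26 log units; within the scatter) as its result. Methyl in place of hydrogen on a nitrogen on an aromatic ring gave a 1.1-fold higher number from compound 1 to compound 3 (0.02 log units; within the scatter) as its result, so the swap is expected to carry over. The expected change is a 1.8-fold higher number from compound 3 to compound 4 (0.25 log units; within the scatter) in the same direction, and it would stay within the scatter. Compound 4 is estimated at 21000 nM (expected range 10500 nM to 42000 nM).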

Compound 4, concentration for 50% growth inhibition: 24800 nM
Compound 4: the middle estimate sits 1.2-fold (0.07 log units) below what was measured; low and high end bracket the measured number.
By their numbers in this assay, from the lowest: compounds 1, 3, 2 and 4 (each within the scatter of the next, the first and the last beyond it).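

With the methyl present, 3-hydroxypropyl in place of cyclopentyl gives a 2.1-fold higher number from compound 3 to compound 4 (0.33 log units; beyond the scatter), so this swap now passes the scatter, though only modestly. The swap reads alike with and without the methyl: the same change on two cores in this assay, a 1.8-fold higher number (0.26 log units; within the scatter) from compound 1 to compound 2 and a 2.1-fold higher number (0.33 log units; beyond the scatter) from compound 3 to compound 4, 1.2-fold (0.06 log units) apart, within the scatter of two such steps
Methyl in place of hydrogen, now seen with 3-hydroxypropyl too, gives a 1.2-fold higher number from compound 2 to compound 4 (0.09 log units; within the scatter), so it shows no readable effect alongside either group.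

Still open, from the compounds shown here alone, is how an amine or a longer chain would read in place of 3-hydroxypropyl on this nitrogen. All four compounds also share the methoxy group, so its part in the growth inhibition cannot be judged from them.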